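Acetyl for trifluoromethyl on the shared core, cytotoxicity

The source may report more compounds than this note shows. Statements on the series, on what has been measured and on what is new or still open speak of the compounds shown alone.

Compound 3 `COc1ccc(-c2nc3cc(C(F)(F)F)ccc3[nH]2)c(OC)c1` is the point of departure. In an ADME assay on Vero cells (Chlorocebus sabaeus) for cytotoxicity (on this read-out lower numbers stand for higher toxicity in this test and higher numbers for lower toxicity in this test), compound 3 gives > 100000 nM, which is a limit of the assay and not a number. For the measured compounds named here, the only measured step ending at compound 3 comes from compound 1 `COc1ccc(-c2nc3cc(C(F)(F)F)ccc3[nH]2)c(OC)c1OC`, which in this assay gives 70000 nM; that step, hydrogen in place of methoxy on an aromatic carbon, is an at least 1.4-fold higher number from compound 1 to compound 3 (0.15 log units; that floor lies within the scatter). Compound 2 `Cn1c(-c2ccc(NC(=O)CN3CCCC3)cc2)nc2cc(C(F)(F)F)ccc21`, a different chain on the same core, is also shown only as a limit. In this assay compound 2 gives > 100000 nM. The read-outs cluster at the limit of > 100000 nM in this assay, at which 2 of the 3 values shown sit, so compound 3 stands where most of the series stands, without a measurable number.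

Compound 4 `COc1ccc(-c2nc3cc(C(C)=O)ccc3[nH]2)c(OC)c1` differs from compound 3 by acetyl in place of trifluoromethyl on an aromatic carbon. No measured step in the series changes the trifluoromethyl, so none bears directly on this change; the one step shown, from compound 1 to compound 3, is a change elsewhere on the core and sits at the scatter floor. The expectation is therefore no step beyond the scatter in this assay, with the estimated step from compound 3 to compound 4 being a number no higher from compound 3 to compound 4 (the limit leaves the size open). Compound 4 is expected to give about 100000 nM, in the range 40000 nM to 250000 nM, most likely reported again as a limit.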

Compound 4, half-maximal cytotoxic concentration: > 100000 nM
Compound 4: only a limit was reported; the forecaster's own chance of this, stated with the estimate: 60%; the middle value sits exactly at the limit.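

In this assay compound 4 gives > 100000 nM, a limit of the assay and not a number. For the compounds shown here, compound 3 is also reported only as a limit, and no step between compound 3 and compound 4 can be read. The read-outs still cluster at one point: the limit of > 100000 nM in this assay, at which 3 of the 4 values shown sit. The compounds shown leave open whether acetyl and trifluoromethyl on the shared core differ at all in this assay.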